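A few compounds are considered here, and "the series" means these few. Any claim that something is new, unique, unknown or untested is made for them only; others in the source may bear on it.

Of the compounds shown here, three have been measured in an assay on isolated protein for inhibition of cathepsin S (Homo sapiens); on this read-out higher numbers stand for weaker inhibition and lower numbers for stronger inhibition. Compound 1 `CC(=O)N1CCc2c(c(-c3ccc(Cl)c(C)c3)nn2CC(O)CN2CCC(n3c(O)nc4cc(C)ccc43)CC2)C1` gives 100 nM. Compound 2 `CS(=O)(=O)N1CCc2c(c(-c3ccc(C(F)(F)F)cc3)nn2CC(O)CN2CCC(n3c(O)nc4ccc(Cl)cc43)CC2)C1` gives 60 nM. Compound 3 `CS(=O)(=O)N1CCc2c(c(-c3ccc(Cl)c(Cl)c3)nn2CCCN2CCC(n3c(O)nc4ccccc43)CC2)C1` gives 10 nM, the lowest of the three numbers and beyond the scatter from both compound 2 and compound 1, so compound 3 is the strongest inhibitor measured so far.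

Compound 4 `CS(=O)(=O)N1CCc2c(c(-c3ccc(C(F)(F)F)cc3)nn2CCCN2CCC(n3c(O)nc4ccccc43)CC2)C1` has not yet been measured. It differs from compound 3 in one place: 4-(trifluoromethyl)phenyl in place of 3,4-dichlorophenyl on an aromatic carbon. Among the compounds with values here, no measured pair isolates exactly this change. Compound 2 also carries the 4-(trifluoromethyl)phenyl group, and compound 2 gives a higher number than compound 3; but compound 2 differs from compound 3 elsewhere as well, so those two values alone cannot tell what the group does.

With only that hint, the step is expected to be a 2.0-fold higher number from compound 3 to compound 4 (0.30 log units; within the scatter), a modest move toward weaker inhibition that may not exceed the scatter. Compound 4 is therefore estimated at 20 nM, within a range from 6 nM to 60 nM.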

Compound 4, half-maximal inhibitory concentration: 50 nM
Compound 4: middle estimate off by 2.5-fold (0.40 log units), on the low side; the measured number falls inside the stated range.
By their numbers in this assay, from the lowest: compound 3; then compounds 4, 2 and 1 (each within the scatter of the next).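

In this assay, within the data shown here, this pair gives the first clean reading of the group on this aromatic carbon: a 5.0-fold higher number from compound 3 to compound 4 (0.70 log units; beyond the scatter), with the rest of the structure unchanged. The choice between these two groups therefore matters for inhibition, and of the two, 3,4-dichlorophenyl gives the stronger inhibition in this setting. No measurement available here explains the difference.

Among these compounds, it remains open whether the same step would appear in a compound with the hydroxyl-bearing chain of compound 2, since only this one pair isolates the change. As far as these compounds go, it is also open how a plain phenyl group or a pyridine ring would compare at this position, so this single step cannot yet be called a trend.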